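The source may hold more compounds than are shown below. What is called first, only, known or untested is meant among the compounds shown, and "the series" means these compounds.

Measured so far:
Compound 1 `Cc1ccsc1C(=CCCN(C)C(CCO)C(=O)NCc1ccc(F)cc1)c1sccc1C`: 5.87
Compound 2 `Cc1ccsc1C(=CCCN(C)C(CO)C(=O)NCc1ccc(F)cc1)c1sccc1C`: 6.45
Compound 3 `Cc1ccsc1C(=CCCN(C)C(CCO)C(=O)NCc1ccc(Cl)cc1)c1sccc1C`: 6.38

Three compounds sharing one core were read in a physicochemical assay for lipophilicity, read by HPLC; on this read-out higher numbers stand for higher lipophilicity and lower numbers for lower lipophilicity. In this assay compound 1 gives 5.87. The change hydroxy in place of hydroxymethyl on a saturated chain carbon, two bonds along the chain from an amine nitrogen and a carbonyl carbon produced a number 0.58 log units higher from compound 1 to compound 2 (beyond the scatter). A different change, (chloro in place of fluoro on an aromatic carbon), produced a number 0.51 log units higher from compound 1 to compound 3 (beyond the scatter). Compound 2 and compound 3 sit within the scatter of each other, so nothing separates them.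

Compound 4 `Cc1ccsc1C(=CCCN(C)C(CO)C(=O)NCc1ccc(Cl)cc1)c1sccc1C` remains to be measured. It differs from compound 3 by hydroxy in place of hydroxymethyl on a saturated chain carbon, two bonds along the chain from an amine nitrogen and a carbonyl carbon, the same change that took compound 1 to compound 2, made here on the core of compound 3, which differs from the core of compound 1 by chloro in place of fluoro on an aromatic carbon. Within the data shown here, since the place of the change is the same in both pairs, a step of similar size is expected, resting on the single earlier example a number 0.58 log units higher from compound 1 to compound 2 (beyond the scatter). Compound 4 is therefore expected to show a number 0.57 log units higher from compound 3 to compound 4 (beyond the scatter) relative to compound 3. The estimated value for compound 4 is 6.95, with a likely range from 6.6 to 7.3.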

Compound 4, partition coefficient: 6.47
The estimate for compound 4 lay 0.48 log units above the measured number, outside the stated range (below it).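

In this assay, the change from 2-hydroxyethyl to hydroxymethyl gave a number 0.58 log units higher from compound 1 to compound 2 (beyond the scatter) with fluoro on the aromatic carbon, but with chloro there the same change gave only a number 0.09 log units higher from compound 3 to compound 4 (within the scatter), so the step seen on the first core did not carry over to the second. Read the other way, chloro in place of fluoro gave a number 0.51 log units higher from compound 1 to compound 3 (beyond the scatter) with the 2-hydroxyethyl chain but a number 0.02 log units higher from compound 2 to compound 4 (within the scatter) with the hydroxymethyl chain, so in these four compounds the two changes do not add up. This is a single pair on each core, so it does not show how the change would behave on any further core, and nothing at hand explains why the two steps differ.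

The compounds shown leave open whether a bromo group on the aromatic carbon would give a step like that on the fluoro core or that on the chloro core. They also leave open what an amine in place of the chain's hydroxy, or a longer chain such as 3-hydroxypropyl, would read on either core.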